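A few compounds are considered here, and "the series" means these few. Any claim that something is new, unique, unknown or untested is made for them only; others in the source may bear on it.

In a functional assay on MDA-MB-231 cells (Homo sapiens) for inhibition (a lower number here means a stronger inhibitor, a higher number a weaker inhibitor), two compounds with the same core have been measured. Compound 1 `N[C@H]1CC[C@H](Nc2nc(NCc3cccc(I)c3)c3ncn(C4CCCC4)c3n2)CC1` gives 1000 nM and compound 2 `N[C@H]1CC[C@H](Nc2nc(NCC3CC3)c3ncn(C4CCCC4)c3n2)CC1` gives 1700 nM, so compound 2 stands within the scatter of compound 1. Compound 3 `C[C@H](Nc1nc(N[C@H]2CC[C@H](N)CC2)nc2c1ncn2C1CCCC1)c1ccccc1` departs from compound 2 at one place: 1-phenylethyl in place of cyclopropylmethyl on a nitrogen on an aromatic ring. In short, 1-phenylethyl comes in place of cyclopropylmethyl on a nitrogen on an aromatic ring. Among the compounds with values here, one measured step bears on this, a 1.7-fold higher number from compound 1 to compound 2 (0.23 log units; within the scatter), where cyclopropyl replaced 3-iodophenyl on a saturated chain carbon bound to a nitrogen on an aromatic ring. That exchange of an aromatic group for cyclopropyl stayed within the scatter, so no step beyond the scatter is expected here. Within the data shown here, no measured compound carries the defined stereocentre of 1-phenylethyl, which leaves the forecast uncertain. The estimated change, a 1.4-fold lower number from compound 2 to compound 3 (0.15 log units; within the scatter), is expected to stay small. For compound 3 the expected value is 1200 nM, with an estimated range of 450 nM to 3200 nM.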

Compound 3, half-maximal inhibitory concentration: 5200 nM
The estimate for compound 3 lay 4.3-fold (0.64 log units) below the measured number; the whole stated range lies below it.
By their numbers in this assay, from the lowest: compounds 1 and 2 (each within the scatter of the next); then compound 3.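

In this assay the group on this nitrogen on an aromatic ring proves able to move the number: the exchange of cyclopropylmethyl for 1-phenylethyl gives a 3.1-fold higher number from compound 2 to compound 3 (0.49 log units; beyond the scatter) and the exchange of 3-iodobenzyl for 1-phenylethyl gives a 5.2-fold higher number from compound 1 to compound 3 (0.72 log units; beyond the scatter) as the second step beyond the scatter. An aromatic ring in the group is therefore not enough to keep the number low, as 3-iodobenzyl and 1-phenylethyl both carry one, while compound 1 and compound 2 stay within the scatter of each other despite the different groups. Nothing measured here accounts for the rise.

As far as these compounds go, whether the step follows from the defined stereocentre, the branched carbon or the absence of iodine stays open. Plain benzyl and the opposite stereoisomer of 1-phenylethyl on this nitrogen would separate these possibilities.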